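From iodo to carboxy: the step to compound 4

A few compounds are considered here, and "the series" means these few. Any claim that something is new, unique, unknown or untested is made for them only; others in the source may bear on it.

In an ADME assay on L929 cells (Mus musculus) for cytotoxicity, read by resazurin assay, with a stated time of 72 h (on this read-out lower numbers stand for stronger inhibition and higher numbers for weaker inhibition), compound 1 `CCc1ccc(C(=O)/C=C/c2ccc3c(c2)B(O)OC3)cc1` gives > 10 ug/mL, a limit of the assay and not a number. Compound 2 `O=C(/C=C/c1ccc2c(c1)B(O)OC2)c1ccc([N+](=O)[O-])cc1` gives > 10 ug/mL, also a limit. Compound 3 `O=C(/C=C/c1ccc2c(c1)B(O)OC2)c1ccc(I)cc1` gives > 10 ug/mL, again a limit. Compound 3 therefore stands with the others at the limit of > 10 ug/mL in this assay, at which 3 of the 3 values shown sit.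

Compound 4 `O=C(O)c1ccc(C(=O)/C=C/c2ccc3c(c2)B(O)OC3)cc1` differs from it by carboxy in place of iodo on an aromatic carbon. Three measured steps also swap one group for another on an aromatic carbon: a step that the two limits leave unreadable from compound 1 to compound 2, a step that the two limits leave unreadable from compound 1 to compound 3 and a step that the two limits leave unreadable from compound 2 to compound 3. None has a readable size, so none points to a direction, and no step beyond the scatter is expected in this assay. The expected change is a step that the limit leaves unreadable from compound 3 to compound 4. The estimate for compound 4 is 20 ug/mL, within an expected range of 10 ug/mL to 50 ug/mL.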

Compound 4, half-maximal inhibitory concentration: > 10 ug/mL
Compound 4 ended at the assay's limit (the forecaster's own chance of this, stated with the estimate: 85%); the middle value does not contradict the limit.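

Compound 4 joins compound 1, compound 2 and compound 3 at a limit in this assay, so no new step can be read from any of them: the limit of > 10 ug/mL in this assay, at which 4 of the 4 values shown sit.

Going by these compounds, the actual cytotoxicity of these four compounds, and whether swapping these groups changes it at all, stays open.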